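A few compounds are considered here, and "the series" means these few. Any claim that something is new, unique, unknown or untested is made for them only; others in the source may bear on it.

Measured so far in an ADME assay on MDCK cells (Canis lupus familiaris) for cytotoxicity, read by CellTiter-Glo, with a stated time of 40 h; on this read-out higher numbers stand for lower toxicity in this test and lower numbers for higher toxicity in this test:
- compound 1 `C=CC(C)(C)c1[nH]c2ccc(C[C@H](O)C(C)(C)O)cc2c1/C=c1\[nH]c(=O)c(=C)[nH]c1=O`: > 200000 nM (a limit)
- compound 2 `C=CC(C)(C)c1[nH]c2ccc(C[C@H](O)C(C)(C)OC)cc2c1/C=c1\[nH]c(=O)c(=C)[nH]c1=O`: > 200000 nM (a limit)

Neither entry is a true number, so compound 1 has no exact place on the scale. Compound 1 stands at the limit of > 200000 nM in this assay, at which 2 of the 2 values shown sit.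

Compound 3 `C=CC(C)(C)c1[nH]c2ccc(C[C@H](O)C(C)(C)O)cc2c1/C=C1\NC(=O)C(=O)NC1=O` keeps the core of compound 1 but exchanges one group: a group of 10 heavy atoms (5 carbon, 2 nitrogen, 3 oxygen; one six-membered non-aromatic ring with 2 hetero atoms) in place of a group of 10 heavy atoms (6 carbon, 2 nitrogen, 2 oxygen; one six-membered aromatic ring with 2 hetero atoms), on an aromatic carbon. One six-membered aromatic ring with 2 hetero atoms gives way to one six-membered non-aromatic ring with 2 hetero atoms, on an aromatic carbon.

Among the measured compounds shown here, the only measured step, a step that the two limits leave unreadable from compound 1 to compound 2, is a different change, and it offers no size to carry over. For the measured compounds named here, with no measured step to suggest a shift in this assay, the expected change is a number no higher from compound 1 to compound 3 (the limit leaves the size open), with no direction favoured. For compound 3 the estimate is 200000 nM, with an expected range from 100000 nM to 400000 nM.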

Compound 3, half-maximal cytotoxic concentration: > 200000 nM
Compound 3: no number, only a limit; the forecaster's own chance of this, stated with the estimate: 80%; the middle value lies on the limit itself.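

In this assay, among the compounds shown here, compound 3 gives only a limit, as compound 1 does, so no step between them can be read: the limit of > 200000 nM in this assay, at which 3 of the 3 values shown sit. The compounds shown leave open where each truly lies on the scale, and whether exchanging the ring group changes toxicity in this test at all.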